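This account rests on a few compounds, and the source may have more. Where it says the series, first, only, none or still open, it means among the compounds named here.

Measured so far:
- compound 1 `O=S(=O)(NCCNC(=S)Nc1cccc(Cl)c1)c1ccc(-c2ccccc2OCc2ccccc2)s1`: > 50000 nM
- compound 2 `COc1ccc(NC(=O)NCCNS(=O)(=O)c2ccc(-c3ccccc3Oc3ccc([N+](=O)[O-])c([N+](=O)[O-])c3)s2)cc1`: 1400 nM

Among the measured compounds shown here, in a functional assay on RS4-11 cells (Homo sapiens) for inhibition, read by CCK-8 assay, with a stated time of 48 h (on this read-out lower numbers stand for stronger inhibition and higher numbers for weaker inhibition), compound 2 gives 1400 nM, the only number in the set. Compound 1 reaches only the limit of > 50000 nM in this assay, at which 1 of the 2 values shown sits, in this assay and yields no number. Compound 3 `COc1ccc(NC(=O)NCCNS(=O)(=O)c2ccc(-c3ccccc3OCc3ccccc3)s2)cc1` has not been measured. It differs from compound 2 by benzyl in place of 3,4-dinitrophenyl on an oxygen on an aromatic ring. For the measured compounds named here, no measured pair separates this change on its own, so its size is not known from a step. Compound 1, which also carries a benzyl on that oxygen, is the nearest point of comparison, and its value sits at a limit. A weakening beyond the scatter is expected, with the step of a 14-fold higher number from compound 2 to compound 3 (1.15 log units; beyond the scatter) as the estimate. Compound 3 is expected to give about 20000 nM in this assay, within 4000 nM to 60000 nM, with a real chance that only a limit is reported.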

Compound 3, half-maximal inhibitory concentration: > 20000 nM
Compound 3: a limit, no number; the forecaster's own chance of this, stated with the estimate: 40%; the middle value lies on the limit itself.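

Compound 3 reaches only a limit in this assay: the limit of > 20000 nM in this assay, at which 1 of the 3 values shown sits.

Among the compounds shown here, with the rest of the structure unchanged, benzyl in place of 3,4-dinitrophenyl on an oxygen on an aromatic ring gives an at least 14-fold higher number from compound 2 to compound 3 (1.15 log units; beyond the scatter), the first direct reading of this change, and it shows that measurable inhibition depends on the group at this place. For the compounds shown here, compound 1 and compound 3 both carry benzyl there, and both give limits, so the step between them cannot be read and no benzyl compound yet has a number.

On these data alone, the full size of the step stays open, as compound 3 has no number. Also open, as far as these compounds go, is whether the nitro groups or the extra carbon of the benzyl account for the step; a plain phenyl on that oxygen, or a benzyl carrying nitro groups, would separate the two.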